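Cyclopentyl in place of hydroxyethyl on the oxime oxygen

The compounds below may be only part of what the source reports. "The series", "measured", "known", "first", "only" and "open" are said of these compounds alone.

Of the compounds shown here, three sharing one core have been measured in a physicochemical assay for lipophilicity, using the shake flask method; a lower number here means a more polar compound, a higher number a more lipophilic compound. Compound 1 `Nc1ncnc(Oc2ccc(NC(=O)C3(C(=O)Nc4ccc(F)cc4)CC3)cc2F)c1/C=N/OCCCO` gives 2.67. Compound 2 `Nc1ncnc(Oc2ccc(NC(=O)C3(C(=O)Nc4ccc(F)cc4)CC3)cc2F)c1/C=N/OCCO` gives 2.37. Compound 3 `Nc1ncnc(Oc2ccc(NC(=O)C3(C(=O)Nc4ccc(F)cc4)CC3)cc2F)c1/C=N/OCCCN1CCCC1` gives 3.82. Compound 2 thus stands at the lower end of these numbers: there is a number 0.30 log units lower from compound 1 to compound 2 (within the scatter), while a number 1.45 log units higher from compound 2 to compound 3 (beyond the scatter) and a number 1.15 log units higher from compound 1 to compound 3 (beyond the scatter) are both large.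

Compound 4 `Nc1ncnc(Oc2ccc(NC(=O)C3(C(=O)Nc4ccc(F)cc4)CC3)cc2F)c1/C=N/OC1CCCC1` differs from compound 2 in one place: cyclopentyl in place of 2-hydroxyethyl on an oxygen. Going by the values given here, two measured steps bear on this change. The step of a number 0.30 log units lower from compound 1 to compound 2 (within the scatter) shows that moving the hydroxy one carbon along the chain changes little, whereas a number 1.45 log units higher from compound 2 to compound 3 (beyond the scatter) shows a large rise once (pyrrolidin-1-yl)methyl replaces the hydroxy. Compound 4 gives up the hydrogen-bond donor and acceptor entirely and gains a five-membered ring of carbon only, so given a number 1.45 log units higher from compound 2 to compound 3 (beyond the scatter) a rise at least as large is expected, a number 1.73 log units higher from compound 2 to compound 4 (beyond the scatter). Compound 4 is therefore estimated at 4.1, with a range from 3.5 to 4.7.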

Compound 4, partition coefficient: 4.27
For compound 4 the middle estimate is 0.17 log units below the measured one; the measured number falls inside the stated range.
By their numbers in this assay, from the lowest: compounds 2 and 1 (each within the scatter of the next); then compound 3; then compound 4.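

In this assay cyclopentyl on the oxime oxygen puts compound 4 well clear of both hydroxy chains, with a number 1.90 log units higher from compound 2 to compound 4 (beyond the scatter) and a number 1.60 log units higher from compound 1 to compound 4 (beyond the scatter) as the two large steps. The same group also passes the 3-(pyrrolidin-1-yl)propyl chain, with a number 0.45 log units higher from compound 3 to compound 4 (beyond the scatter) as a modest step, so this position can reach beyond the value of compound 3 with a smaller group of carbon only and no hydrogen-bond donor or acceptor. Nothing available explains why these numbers move as they do.

The compounds shown leave open whether the ring matters or only the removal of the hydroxy, which an open pentyl chain on the same oxygen would separate. From the compounds shown here alone, how a carboxylic acid or a morpholine at the end of the chain would read here also remains open.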